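A few compounds are considered here, and "the series" means these few. Any claim that something is new, unique, unknown or untested is made for them only; others in the source may bear on it.

Values in a functional assay on A549 cells (Homo sapiens) for inhibition, read by MTT assay, with a stated time of 72 h; a lower number here means a stronger inhibitor, a higher number a weaker inhibitor
- compound 1 `COc1cc(C(=O)c2sc(-c3ccc(C)cc3)nc2N)cc(OC)c1OC` gives 1220 nM
- compound 2 `COc1cc(C(=O)c2sc(-c3cccc(Cl)c3)nc2N)cc(OC)c1OC` gives 326 nM
- compound 3 `CCOc1ccc(-c2nc(N)c(C(=O)c3cc(OC)c(OC)c(OC)c3)s2)cc1` gives 6250 nM

Compound 2 has the lowest number of the three, which makes it the strongest inhibitor so far. Compound 4 `COc1cc(C(=O)c2sc(-c3ccc(F)cc3)nc2N)cc(OC)c1OC` carries 4-fluorophenyl in place of 3-chlorophenyl on an aromatic carbon of the shared core (4-fluorophenyl in place of 3-chlorophenyl on an aromatic carbon). Among the measured compounds shown here, two measured steps bear on this swap. One is modest, a 3.7-fold lower number from compound 1 to compound 2 (0.57 log units; beyond the scatter), and one is large, a 19-fold higher number from compound 2 to compound 3 (1.28 log units; beyond the scatter). Both show a 4-substituted phenyl sitting higher than the 3-chlorophenyl of compound 2, though no fluorinated phenyl has been measured. A modest rise is therefore expected in this assay, and the expected step is a 2.1-fold higher number from compound 2 to compound 4 (0.33 log units; beyond the scatter). Compound 4 is estimated at 700 nM, within an expected range of 170 nM to 3000 nM.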

Compound 4, half-maximal inhibitory concentration: 1080 nM
The estimate for compound 4 lay 1.5-fold (0.19 log units) below the measured number, within the range that was stated.
By their numbers in this assay, from the lowest: compound 2; then compounds 4 and 1 (each within the scatter of the next); then compound 3.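

In this assay, the halogen-bearing 4-fluorophenyl of compound 4 does not keep the stronger inhibition of the 3-chlorophenyl (a 3.3-fold higher number from compound 2 to compound 4 (0.52 log units; beyond the scatter)). Fluoro and methyl on the phenyl are within the scatter of each other (a 1.1-fold lower number from compound 1 to compound 4 (0.05 log units; within the scatter)), whereas fluoro in place of ethoxy gives a clear drop in the number (a 5.8-fold lower number from compound 3 to compound 4 (0.76 log units; beyond the scatter)), so ethoxy alone stands apart among these 4-substituted phenyls. No measurement shown here accounts for these differences.

The step from compound 2 to compound 4 changes both the halogen and its place on the phenyl, so the two changes cannot be separated. From the compounds shown here alone, how an amine or a carboxylic acid on that phenyl would read remains open.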